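A few compounds are considered here, and "the series" means these few. Any claim that something is new, unique, unknown or untested is made for them only; others in the source may bear on it.

Measured compounds in an assay on L1.2 cells for binding affinity to C-C chemokine receptor type 8 (Homo sapiens); on this read-out lower numbers stand for stronger inhibition and higher numbers for weaker inhibition:
- compound 1, `CCOC(=O)N1CCC(NS(=O)(=O)c2ccc(C(=O)NC3CCCCC3)c3ccccc23)CC1`: compound 1 gives 9.5 nM
- compound 2, `CCOC(=O)N1CCC(NS(=O)(=O)c2ccc(OC(=O)c3ccccc3)c3ccccc23)CC1`: compound 2 gives 16.4 nM
- compound 3, `CCC(=O)N1CCC(NS(=O)(=O)c2ccc(NC(=O)c3ccccc3C)c3ccccc23)CC1`: compound 3 gives 2.5 nM

Among these three, compound 3 has the lowest number in this assay; the gap to compound 1 and the gap to compound 2 both lie beyond the scatter. For the measured compounds named here, the only measured step that changes a single place is a 1.7-fold higher number from compound 1 to compound 2 (0.24 log units; within the scatter), and it concerns the substituent on an aromatic carbon of the shared core, not the group attached to the carbonyl carbon at the other end of the molecule.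

Compound 4, `Cc1ccccc1C(=O)Nc1ccc(S(=O)(=O)NC2CCN(C(N)=O)CC2)c2ccccc12`, differs from compound 3 in exactly that other place: amino in place of ethyl on a carbonyl carbon. Going by the values given here, no measured pair speaks to this change, so there is no step on record from which its size or direction can be read. Without such a precedent, the expected step is a 1.6-fold higher number from compound 3 to compound 4 (0.20 log units; within the scatter), a small shift that would not stand out from repeated measurement. Compound 4 is therefore estimated to give 4 nM in this assay, with a range from 1.5 nM to 12 nM.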

Compound 4, inhibition constant: 243 nM
Compound 4: middle estimate off by 61-fold (1.78 log units), on the low side; the whole stated range lies below it.
By their numbers in this assay, from the lowest: compound 3; then compounds 1 and 2 (each within the scatter of the next); then compound 4.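

In this assay, for the compounds shown here, amino in place of ethyl on the carbonyl carbon brings a 97-fold higher number from compound 3 to compound 4 (1.99 log units; beyond the scatter), so this end of the molecule, which no earlier pair had touched, can strongly change the read-out. Going by these compounds alone, the only earlier single-place step, a 1.7-fold higher number from compound 1 to compound 2 (0.24 log units; within the scatter), concerned an aromatic carbon and stayed within the scatter, so the earlier compounds gave no sign of a change this large. Nothing on record accounts for the size of the new step.

The compounds shown leave open how methyl, methylamino or dimethylamino on this carbonyl carbon would read, and so whether a substituted amine would behave like amino or like ethyl. They also leave open how ethoxy, which compound 1 and compound 2 carry there, would read with the rest of compound 3 unchanged.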